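Swapping hydroxycyclohexyl for oxolanylmethyl: a permeability outlook

This account rests on a few compounds, and the source may have more. Where it says the series, first, only, none or still open, it means among the compounds named here.

Measured compounds:
Compound 1, `COc1ccc(Cn2c(-c3ccccc3)c(-c3ccccc3)c3c(=N)n([C@H]4CC[C@H](O)CC4)cnc32)cc1`. In an ADME assay for permeability, using PAMPA, with a stated time of 30 min, at pH 7.4 (a higher number here means that the compound crosses the layer faster, a lower number that the compound crosses the layer more slowly), compound 1 reaches > 1000 10^-6 cm/s, which is a limit of the assay and not a number.
Compound 2, `COc1ccc(-c2c(-c3ccc(OC)cc3)n(Cc3ccccc3)c3ncn([C@H]4CC[C@H](O)CC4)c(=N)c23)cc1`. In this assay compound 2 gives 196 10^-6 cm/s.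

Among the measured compounds shown here, compound 2 holds the only actual number among the two measured compounds. For the measured compounds named here, the other entry, for compound 1, is a limit (the limit of > 1000 10^-6 cm/s in this assay, at which 1 of the 2 values shown sits), so no measured step between compound 1 and compound 2 can be stated; only the two readings themselves are known.

Compound 3, `COc1ccc(-c2c(-c3ccc(OC)cc3)n(Cc3ccccc3)c3ncn(CC4CCOC4)c(=N)c23)cc1`, has not yet been measured. It differs from compound 2 in one place: (oxolan-3-yl)methyl in place of 4-hydroxycyclohexyl on an aromatic nitrogen. Going by the values given here, no step between measured compounds exists that would show how large an effect such a change has here. In this assay the expectation for compound 3 is nevertheless a rise beyond the usual scatter, by a step of a 2.6-fold higher number from compound 2 to compound 3 (0.41 log units; beyond the scatter). Compound 3 is accordingly estimated at 500 10^-6 cm/s, with a range from 200 10^-6 cm/s to 1200 10^-6 cm/s, and with a fair chance that the assay reports only a limit rather than a number.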

Compound 3, apparent permeability: > 1000 10^-6 cm/s
Compound 3: only a limit was reported; the forecaster's own chance of this, stated with the estimate: 25%; at least 2.0-fold (0.30 log units) between middle value and limit.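

Among the compounds shown here, the swap of 4-hydroxycyclohexyl for (oxolan-3-yl)methyl on an aromatic nitrogen gives the first step that can be read at this position: in this assay it is an at least 5.1-fold higher number from compound 2 to compound 3 (0.70 log units; beyond the scatter). This means that changing the group on this nitrogen alone, with the rest of the shared core left as it is, is enough to move the reading beyond the usual scatter. The true size of the step remains unknown, since the higher reading is a limit of the assay and not a number: the limit of > 1000 10^-6 cm/s in this assay, at which 2 of the 3 values shown sit.

The swap changes several things at once, going from a six-membered ring of carbon only with 1 hydrogen-bond donor to a five-membered ring with 1 hetero atom and 0 hydrogen-bond donors, and these compounds cannot show which of those differences matters. On these data alone, it also remains open how a plain cyclohexyl group, which keeps the carbon ring but lacks the hydroxyl, or an amine on the same nitrogen would read in this assay, and whether either would give a number rather than a limit.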